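Adding a Bromo to a Compound Sitting at a Limit

The source may report more compounds than this note shows. Statements on the series, on what has been measured and on what is new or still open speak of the compounds shown alone.

In a functional assay on A549 cells (Homo sapiens) for cytotoxicity (on this read-out lower numbers stand for stronger inhibition and higher numbers for weaker inhibition), compound 2 `Cc1ccc(S(=O)(=O)N2C(=O)NCC2c2ccccc2)cc1` gives no exact number, only a limit: > 316000 nM. Two related compounds do give numbers. Compound 3 `O=C1NC(c2ccccc2)CN1S(=O)(=O)c1ccccc1` reads 145000 nM, and compound 1 `O=C1NC(c2ccc(Br)cc2)CN1S(=O)(=O)c1ccc2c(c1)CCC2` reads 33900 nM. Compound 1 carries a 4-bromophenyl group where compound 3 has a phenyl, but the two also differ elsewhere, so their values cannot be credited to the bromo alone.

Compound 4 `Cc1ccc(S(=O)(=O)N2C(=O)NCC2c2ccc(Br)cc2)cc1` is compound 2 with a single change: bromo in place of hydrogen on an aromatic carbon. Bromo takes the place of hydrogen on an aromatic carbon, para to a large group, turning phenyl into 4-bromophenyl.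

Among the measured compounds shown here, no measured pair shows this change on its own, so any forecast here is tentative. For the measured compounds named here, the only measured compound with the 4-bromophenyl group is compound 1 at 33900 nM, and this supports expecting a clear step toward stronger inhibition in this assay, beyond the usual scatter. The expected change is an at least 4.5-fold lower number from compound 2 to compound 4 (0.65 log units; beyond the scatter), and its true size stays uncertain since the starting point is only a limit. For compound 4 the estimated value is 70000 nM. The expected range for compound 4 runs from 25000 nM to 200000 nM.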

Compound 4, half-maximal inhibitory concentration: 67000 nM
For compound 4 the middle estimate is 1.0-fold (0.02 log units) above the measured one; the range from low to high includes it.
By their numbers in this assay, from the lowest: compounds 1 and 4 (each within the scatter of the next); then compound 3. At a limit, above all of these: compound 2.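

Among the compounds shown here, the new pair isolates this change for the first time: in this assay, with everything else held fixed, replacing phenyl with 4-bromophenyl gives an at least 4.7-fold lower number from compound 2 to compound 4 (0.67 log units; beyond the scatter). Compound 1 and compound 3 could not show this, since they differ in more than one place and the effect of the bromo could not be separated from their other differences. The true size of the step remains unknown, and the printed figure is only a minimum, because compound 2 gives a limit of the assay rather than a number: the limit of > 316000 nM in this assay, at which 1 of the 4 values shown sits.

On these data alone, these compounds show only one replacement at one place, so it remains open whether a chloro, a methoxy or an amine on the same aromatic carbon would lower the number as well, or whether a bromo on a different carbon of that ring would do the same. For the compounds shown here, it also remains open whether the step from phenyl to 4-bromophenyl would be similar alongside the sulfonyl groups of compound 1 and compound 3, which differ from the one shared by this pair.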